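Replacing the Aryl Urea with a Benzamide

This account rests on a few compounds, and the source may have more. Where it says the series, first, only, none or still open, it means among the compounds named here.

Compound 1: `COc1cc(-c2nn(-c3cccc(NC(=O)Nc4ccc(Cl)c(Cl)c4)c3)cc2-c2ccncc2)ccc1Cl`; in a functional assay on ACHN cells (Homo sapiens) for inhibition, read by sulforhodamine B assay, with a stated time of 48 h (a higher number here means a weaker inhibitor of growth, a lower number a stronger inhibitor of growth), compound 1 gives > 50000 nM, which is a limit of the assay rather than a number.
Compound 2: `COc1cc(-c2nn(-c3cccc(NC(=O)Nc4ccc(Cl)c(C(F)(F)F)c4)c3)cc2-c2ccncc2)ccc1Cl`; in this assay compound 2 gives 15600 nM.

Among the measured compounds shown here, compound 2 holds the only numerical value shown; the other value is a limit. For the measured compounds named here, the one measured step, an at least 3.2-fold lower number from compound 1 to compound 2 (0.50 log units; beyond the scatter), rests on that limit (the limit of > 50000 nM in this assay, at which 1 of the 2 values shown sits), so its true size is known only as a lower bound.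

Compound 3 is `COc1cc(-c2nn(-c3cccc(NC(=O)c4ccccc4)c3)cc2-c2ccncc2)ccc1Cl`. It differs from compound 2 by phenyl in place of (4-chloro-3-(trifluoromethyl)phenyl)amino on a carbonyl carbon. Going by the values given here, nothing measured bears directly on this change: the single step concerns a substituent on the aryl ring that compound 3 no longer carries. Among the compounds with values here, the only guide is that compound 1 and compound 2 differ in that distal aryl ring and give quite different readings, so the ring's presence is not indifferent to the result, and its removal in compound 3 is expected to cost activity.

Compound 3 is therefore estimated to give 40000 nM (range 12000 nM to 130000 nM), an expected step of a 2.6-fold higher number from compound 2 to compound 3 (0.41 log units; beyond the scatter).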

Compound 3, concentration for total growth inhibition: > 100000 nM
Compound 3: no number, only a limit; the forecaster's own chance of this, stated with the estimate: 45%; middle value at least 2.5-fold (0.39 log units) away from the limit.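

Exchanging the (4-chloro-3-(trifluoromethyl)phenyl)amino group on the carbonyl carbon for phenyl, which turns the urea into a benzamide, gives an at least 6.4-fold higher number from compound 2 to compound 3 (0.80 log units; beyond the scatter) in this assay, so this place in the series, and not only the substituents on the distal ring, bears on the reading. Compound 3 gives > 100000 nM, which is a limit of the assay and not a number, so the size of that step is known only as a lower bound: the limit of > 100000 nM in this assay, at which 1 of the 3 values shown sits. Compound 1 and compound 3 both stand at limits, and the step between them cannot be read, so the benzamide can be placed against the trifluoromethyl urea of compound 2 but not against the dichloro urea of compound 1.

The compounds shown leave open whether the loss follows from the missing amino nitrogen or from the missing chloro and trifluoromethyl groups, which leave together in this one change. They also leave open how a benzamide carrying chloro and trifluoromethyl on its phenyl ring, or one carrying an amine or a carboxylic acid there, would read in this assay.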